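A few compounds are considered here, and "the series" means these few. Any claim that something is new, unique, unknown or untested is made for them only; others in the source may bear on it.

In a functional assay on DU-145 cells (Homo sapiens) for cytotoxicity, read by sulforhodamine B assay, with a stated time of 3 days (a lower number here means that less compound is needed, a higher number that more compound is needed for the effect), compound 1 `COC(=O)c1c(C)coc1-c1ccc2c(c1OC)CCCC2(C)C` gives 33.5 uM and compound 2 `Cc1coc(-c2ccc3c(c2O)CCC3)c1C(=O)O` gives 38.4 uM, two numbers within the usual scatter of each other. Compound 3 `COCc1c(C)coc1-c1ccc2c(c1OC)CCCC2(C)C` keeps the core of compound 1 but carries methoxymethyl in place of methoxycarbonyl on an aromatic carbon. Within the data shown here, no measured pair in this small set tests such a change, so the expectation stays close to compound 1 at 33.5 uM. In this assay, the expected step is a 1.1-fold lower number from compound 1 to compound 3 (0.05 log units; within the scatter), with no direction expected beyond the scatter. Compound 3 is estimated at 30 uM, within an expected range of 12 uM to 75 uM.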

Compound 3, concentration for half-maximal effect: 17.5 uM
For compound 3 the middle estimate is 1.7-fold (0.23 log units) above the measured one, and the stated range covers the measured number.
By their numbers in this assay, from the lowest: compounds 3, 1 and 2 (each within the scatter of the next, the first and the last beyond it).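

Among these compounds, at this position on the five-membered aromatic ring, this assay shows the first single-place change in this set: methoxymethyl in place of methoxycarbonyl gives a step within the scatter (a 1.9-fold lower number from compound 1 to compound 3 (0.28 log units; within the scatter)). The position therefore tolerates losing the carbonyl of methoxycarbonyl without the number moving beyond the scatter. Nothing available explains this result.

On these data alone, whether an amine, an amide or a longer ether chain at this carbon would move the number beyond the scatter remains open. As far as these compounds go, it also remains open whether the same change would give a similar step on a different core.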